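Notes on the aryl exchange in compound 2

This account rests on a few compounds, and the source may have more. Where it says the series, first, only, none or still open, it means among the compounds named here.

Measured in a functional assay on K562 cells (Homo sapiens) for cytotoxicity, read by sulforhodamine B assay, with a stated time of 48 h; a lower number here means a stronger inhibitor, a higher number a weaker inhibitor:
- compound 1 `CCN(CC)CCCn1c(=O)/c(=C/c2ccc(O)cc2)s/c1=C1\C(=O)Nc2ccc(Cl)cc21`: 24600 nM
- compound 2 `CCN(CC)CCCn1c(=O)/c(=C/c2ccc(O)cc2)s/c1=C1/C(=O)Nc2ccc(Cl)cc21`: 24600 nM
- compound 3 `CCN(CC)CCCn1c(=O)/c(=C/c2ccc(F)cc2F)s/c1=C1/C(=O)Nc2cc(F)ccc21`: 3690 nM

In this assay compound 2 gives 24600 nM, level with compound 1, and the two share the highest number of the three. Compound 3 stands lower at 3690 nM, beyond the scatter.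

The next compound is compound 4 `CCN(CC)CCCn1c(=O)/c(=C/c2cc(OC)c(OC)c(OC)c2)s/c1=C1/C(=O)Nc2ccc(Cl)cc21`, which keeps the rest of compound 2 and carries 3,4,5-trimethoxyphenyl in place of 4-hydroxyphenyl on a double-bonded chain carbon bound to an aromatic carbon.

For the measured compounds named here, the only measured step is no change at the digits printed from compound 1 to compound 2 (within the scatter), and it concerns (the fact that compounds 1 and 2 differ only in the configuration as drawn). Going by the values given here, it therefore gives no size for an exchange of this aryl group, and no measured step covers that exchange directly. The sole hint of direction is compound 3 at 3690 nM, which shows that lower numbers do occur among these compounds. A modest fall is therefore expected, held with little confidence, and a result within the scatter of compound 2 would be no surprise.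

The expected change is a 1.9-fold lower number from compound 2 to compound 4 (0.28 log units; within the scatter). For compound 4 the estimated value is 13000 nM, with an expected range of 4000 nM to 40000 nM.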

Compound 4, half-maximal inhibitory concentration: 820 nM
Compound 4: the middle estimate sits 16-fold (1.20 log units) above what was measured; the measured number lies below the stated range.
By their numbers in this assay, from the lowest: compound 4; then compound 3; then compounds 1 and 2 (each within the scatter of the next).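

In this assay, the aryl group on a double-bonded chain carbon bound to an aromatic carbon now has a measured step: a 30-fold lower number from compound 2 to compound 4 (1.48 log units; beyond the scatter). For the compounds shown here, this is the first step beyond the scatter between compounds that differ in one place, so the aryl exchange at this position can move the number, which the earlier change in drawn configuration did not show. The exchange replaces 4-hydroxyphenyl, with 1 hydrogen-bond donor and 1 hydrogen-bond acceptor, by the larger 3,4,5-trimethoxyphenyl, with 0 hydrogen-bond donors and 3 hydrogen-bond acceptors, and nothing at hand shows which of these differences accounts for the step.

A single exchange cannot separate the removal of the hydroxyl group from the addition of the three methoxy groups, and 4-methoxyphenyl or 3,5-dimethoxyphenyl at the same place would be needed to begin to divide the step between them. On these data alone, it also remains open whether the same exchange gives a step of similar size on the configuration drawn in compound 1.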